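The compounds below may be only part of what the source reports. "The series", "measured", "known", "first", "only" and "open" are said of these compounds alone.

Compound 2 `O=C(Nn1c(-c2cccc([N+](=O)[O-])c2)nc2c(-c3cccc(Cl)c3)n[nH]c2c1=O)c1ccccc1` gives "not determined" (no result reported) in a functional assay on SK-OV-3 cells (Homo sapiens) for cytotoxicity, read by sulforhodamine B assay, with a stated time of 2 days, tested at 100 uM; on this read-out higher numbers stand for more inhibition at the one concentration tested (going by the name of the read-out) and lower numbers for less inhibition: no result was reported for it. Its relative compound 1 `O=C(Nn1c(-c2cccc([N+](=O)[O-])c2)nc2c(-c3ccc(Cl)cc3)n[nH]c2c1=O)c1cccnc1`, which also carries the 4-chlorophenyl group, gives 30.2% in this assay. Compound 3 `O=C(Nn1c(-c2cccc([N+](=O)[O-])c2)nc2c(-c3ccc(Cl)cc3)n[nH]c2c1=O)c1ccccc1` differs from compound 2 by a single rearrangement, (4-chlorophenyl in place of 3-chlorophenyl on an aromatic carbon). Among the compounds with values here, with no step between measured compounds to lean on, the size and direction of the change in this assay are open, and a move within the scatter is as plausible as one beyond it. Compound 3 is expected to give about 30% in this assay. The estimate for compound 3 is expected to span 10% to 55%.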

Compound 3, a percentage reported as inhibition, at one concentration (the size of the read-out at that concentration, not a potency): 86.8%
Compound 3: middle estimate off by 56.8 percentage points, on the low side; measured number above the stated range.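

Phenyl in place of pyridin-3-yl on a carbonyl carbon, with the 4-chlorophenyl group unchanged, gives a number 56.6 percentage points higher from compound 1 to compound 3 (beyond the scatter) in this assay. Within the data shown here, this shows that the ring on the carbonyl carbon, a place the earlier compounds did not compare, can strongly shift this read-out. Nothing available explains why the swap has this effect. The step from 3-chlorophenyl to 4-chlorophenyl cannot be read, since compound 2 has no result. From the compounds shown here alone, whether a cyclohexyl group or a methyl group on that carbonyl carbon would keep the higher number remains open.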